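This account rests on a few compounds, and the source may have more. Where it says the series, first, only, none or still open, it means among the compounds named here.

Working notes on the series. In an ADME assay on CHO cells (Cricetulus griseus) for cytotoxicity, read by MTT assay, with a stated time of 24 h (a lower number here means a stronger inhibitor, a higher number a weaker inhibitor), compound 1 `O=C(O)C1=CO[C@@H](O[C@@H]2O[C@H](COCc3ccccc3)[C@@H](OCc3ccccc3)[C@H](OCc3ccccc3)[C@H]2OCc2ccccc2)[C@@H]2C(COCc3ccccc3)=CC[C@H]12` gives > 200000 nM, which is a limit and not a number. Compound 2 `CCOS(=O)(=O)/C=C/c1ccc(CNC(=O)C2=CO[C@@H](O[C@@H]3O[C@H](COCc4ccccc4)[C@@H](OCc4ccccc4)[C@H](OCc4ccccc4)[C@H]3OCc3ccccc3)[C@@H]3C(COCc4ccccc4)=CC[C@H]23)cc1` gives > 200000 nM, again a limit. Compound 3 `CCOS(=O)(=O)/C=C/c1ccc(OCC2=CC[C@@H]3C(C(=O)Nc4ccc(Oc5ccccc5)cc4)=CO[C@@H](OC)[C@H]23)cc1` gives > 200000 nM, also a limit. Compound 3 therefore has no rank among the three, and the whole set so far comes down to the limit of > 200000 nM in this assay, at which 3 of the 3 values shown sit.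

Compound 4 `CCOS(=O)(=O)/C=C/c1ccc(OCC2=CC[C@@H]3C(C(=O)Nc4ccc(Oc5ccc(Br)cc5Cl)cc4)=CO[C@@H](OC)[C@H]23)cc1` differs from compound 3 in one place: 4-bromo-2-chlorophenyl in place of phenyl on an oxygen on an aromatic ring. In words, 4-bromo-2-chlorophenyl stands in place of phenyl on an oxygen on an aromatic ring, so phenoxy becomes 4-bromo-2-chlorophenoxy. The rest of the structure is unchanged.

For the measured compounds named here, no measured pair differs in a single place, so no measured step is available as a guide, and the starting point is not a number. The expectation is therefore no change beyond the scatter in this assay, in either direction. That expectation rests on compound 3 at > 200000 nM, a limit. The expected step is a number no higher from compound 3 to compound 4 (the limit leaves the size open). For compound 4 the estimated value is 200000 nM, with an expected range from 100000 nM to 400000 nM, and a second report as a limit is the likelier outcome.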

Compound 4, half-maximal inhibitory concentration: > 200000 nM
Compound 4: no number, only a limit; the forecaster's own chance of this, stated with the estimate: 75%; the middle value sits exactly at the limit.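

In this assay compound 4 gives > 200000 nM, which is a limit and not a number. Compound 3 also stands at a limit, so no step can be read from compound 3 to compound 4. The series so far offers only one reading: the limit of > 200000 nM in this assay, at which 4 of the 4 values shown sit.

The compounds shown leave open whether phenoxy or 4-bromo-2-chlorophenoxy makes any measurable difference in this assay.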